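This account rests on a few compounds, and the source may have more. Where it says the series, first, only, none or still open, it means among the compounds named here.

Working notes on the series.

Of the compounds shown here, two have numbers so far. Compound 1, `Cn1ncc(Cl)c1-c1cc(C(=O)N[C@@H]2CN[C@H](CCN3CCC(O)CC3)C[C@H]2c2ccc(Cl)c(Cl)c2)oc1Cl`, gives 5.99 nM in an assay for inhibition of RAC-alpha serine/threonine-protein kinase (Homo sapiens), read by HTRF, with a stated time of 1 h; on this read-out lower numbers stand for stronger inhibition and higher numbers for weaker inhibition. Compound 2, `CNC(=O)C[C@@H]1C[C@@H](c2ccc(F)c(F)c2)[C@H](NC(=O)c2cc(-c3c(Cl)cnn3C)c(Cl)o2)CN1`, gives 1.37 nM in this assay. Compound 1 therefore stands highest of the two numbers; compound 2 is the nearer of the pair, and its number is lower by a margin that lies beyond the scatter. Going by the values given here, no single-point step links the two, since they differ in more than one place, so only the two values themselves are taken as given.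

The next compound is compound 3, `Cn1ncc(Cl)c1-c1cc(C(=O)N[C@@H]2CN[C@H](CC(=O)NC3CC3)C[C@H]2c2ccc(Cl)c(Cl)c2)oc1Cl`, which is not yet measured in this assay. Compared with compound 1 the change is cyclopropylcarbamoyl in place of (4-hydroxypiperidin-1-yl)methyl on a saturated chain carbon bound to a saturated ring carbon. The shared core and the dichlorophenyl ring are kept.

Among the compounds with values here, with no measured single-point step in hand, the expectation for compound 3 rests on compound 1 at 5.99 nM and on compound 2 at 1.37 nM, which shows that a lower number is reachable. The step of a 2.0-fold lower number from compound 1 to compound 3 (0.30 log units; within the scatter) is expected to be a small move toward a lower number, near the edge of the scatter. Compound 3 is estimated at 3 nM, with a range from 1 nM to 9 nM.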

Compound 3, half-maximal inhibitory concentration: 3.95 nM
Compound 3: middle estimate off by 1.3-fold (0.12 log units), on the low side, and the stated range covers the measured number.
By their numbers in this assay, from the lowest: compound 2; then compounds 3 and 1 (each within the scatter of the next).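

The exchange of (4-hydroxypiperidin-1-yl)methyl for cyclopropylcarbamoyl on a saturated chain carbon bound to a saturated ring carbon gives a 1.5-fold lower number from compound 1 to compound 3 (0.18 log units; within the scatter) in this assay, so compound 3 and compound 1 cannot be told apart on this read-out. Going by these compounds alone, this is the first single-place comparison, and it shows that this position can carry either a six-membered non-aromatic ring with one hetero atom or a three-membered ring of carbon only, and that the two groups, of different size and make-up, leave the number within the scatter. No measurement at hand bears on why the two groups read alike.

From the compounds shown here alone, two compounds at this position cannot show whether the number there responds to any group at all, and it remains open whether a carboxylic acid, a primary amine or a longer chain ending in the same cyclopropylcarbamoyl would stay in this range. Compound 2 differs from compound 3 in more than one place, so how much of its number belongs to the chain at this position and how much to the aromatic ring stays unresolved.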